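The compounds below may be only part of what the source reports. "The series", "measured", "known", "first", "only" and "open" are said of these compounds alone.

Compound 1 `Nc1nc(=O)n(C2OC(CO)C(I)C2O)cc1F` gives 0.1 ug/mL in a functional assay on P815 cells (Mus musculus) for antiproliferative activity (on this read-out higher numbers stand for weaker inhibition and lower numbers for stronger inhibition), and sits at the top of the two numbers in hand; compound 2 `Cc1ccc(S(=O)(=O)O[C@@H]2[C@@H](O)[C@H](n3ccc(N)nc3=O)O[C@@H]2CO)cc1` gives 0.06 ug/mL in this assay, and the gap between the two lies within the usual scatter, so the two cannot be told apart. Compound 3 `Nc1nc(=O)n(C2OC(CO)C(Br)C2O)cc1F` is not yet measured in this assay. Against compound 1 the change is bromo in place of iodo on a saturated ring carbon. Among the compounds with values here, no measured pair shows this change, so nothing in hand fixes its size. The step from compound 1 to compound 3 is expected to stay within the scatter, a 1.2-fold higher number from compound 1 to compound 3 (0.08 log units; within the scatter), with no clear direction. In this assay compound 3 is estimated at 0.12 ug/mL, between 0.04 ug/mL and 0.4 ug/mL.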

Compound 3, concentration for 50% inhibition: 0.2 ug/mL
For compound 3 the middle estimate is 1.7-fold (0.22 log units) below the measured one, and the stated range covers the measured number.
By their numbers in this assay, from the lowest: compounds 2, 1 and 3 (each within the scatter of the next, the first and the last beyond it).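

Within the data shown here, the step of a 2.0-fold higher number from compound 1 to compound 3 (0.30 log units; within the scatter) in this assay gives the first measured pair at this saturated ring carbon and shows that bromo and iodo cannot be told apart here. The iodo group is therefore not needed for the activity of compound 1 in this assay, as bromo serves within the scatter. No available evidence accounts for this step.

Still open, from the compounds shown here alone, is whether chloro, an amine or a plain hydrogen on this saturated ring carbon would also stay within the scatter of compound 1.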